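The source may report more compounds than this note shows. Statements on the series, on what has been measured and on what is new or still open speak of the compounds shown alone.

Measured so far in a functional assay on A549 cells (Homo sapiens) for cytotoxicity; a higher number here means a weaker inhibitor, a lower number a stronger inhibitor:
- compound 1 `C=C/C=C\[C@H](C)[C@H](OC(N)=O)[C@@H](C)[C@H](O)[C@@H](C)C/C(C)=C\[C@H](C)[C@@H](O)[C@@H](C)/C=C\CCc1cccc(O)c1C` gives 910 nM
- compound 2 `C=C/C=C\[C@H](C)[C@H](OC(N)=O)[C@@H](C)[C@H](O)[C@@H](C)C/C(C)=C\[C@H](C)[C@@H](O)[C@@H](C)/C=C\CCc1cccc(OC)c1` gives 600 nM

Going by the values given here, the only measured step is a 1.5-fold lower number from compound 1 to compound 2 (0.18 log units; within the scatter) and it lies within the scatter, so compound 2 sits level with compound 1 on these numbers and has no separate standing.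

Compound 3 `C=C/C=C\[C@H](C)[C@H](OC(N)=O)[C@@H](C)[C@H](O)[C@@H](C)C/C(C)=C\[C@H](C)[C@@H](O)[C@@H](C)/C=C\CCc1cccc(O)c1` differs from compound 2 by hydrogen in place of methyl on an oxygen on an aromatic ring (hydrogen in place of methyl on an oxygen on an aromatic ring, methoxy to hydroxy, 3-methoxyphenyl to 3-hydroxyphenyl). Among the compounds with values here, no measured step isolates this change. Within the data shown here, the one step that bears on it is the step above, which exchanges 3-hydroxy-2-methylphenyl for 3-methoxyphenyl and so changes more than the methyl on oxygen. Among the measured compounds shown here, that step is small, and with only two measured compounds the evidence is thin. No direction can be argued from it, and no change beyond the scatter is expected. The estimated step is a 1.2-fold higher number from compound 2 to compound 3 (0.07 log units; within the scatter) and it remains an expectation only. For compound 3 the expected value is 700 nM, with an estimated range from 250 nM to 1800 nM in this assay.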

Compound 3, half-maximal inhibitory concentration: 190 nM
The estimate for compound 3 lay 3.7-fold (0.57 log units) above the measured number; measured number outside the range, below it.
By their numbers in this assay, from the lowest: compound 3; then compounds 2 and 1 (each within the scatter of the next).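

In this assay, each of the two single changes leading to compound 3 gives a step beyond the scatter: hydrogen in place of methyl on the oxygen on the aromatic ring (a 3.2-fold lower number from compound 2 to compound 3 (0.50 log units; beyond the scatter)) and hydrogen in place of methyl on an aromatic carbon (a 4.8-fold lower number from compound 1 to compound 3 (0.68 log units; beyond the scatter)). The earlier step between compound 1 and compound 2 exchanged one methyl-bearing aromatic group for the other and stayed within the scatter, so it could not show that the 3-hydroxyphenyl compound stands apart from both; among these three compounds, either methyl goes with a higher number, and none goes against this. Nothing measured here accounts for either step.

Open is whether the hydroxy group itself is needed at this place, since no compound shown carries an amine, a fluorine or an unsubstituted phenyl there. Also open, as far as these compounds go, is whether a larger group on the oxygen, such as ethoxy or benzyloxy, would follow the methoxy compound, and whether the 3-hydroxyphenyl result holds in other cell lines.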